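A few compounds are considered here, and "the series" means these few. Any claim that something is new, unique, unknown or untested is made for them only; others in the source may bear on it.

Compound 1 `C=C(c1cc(OC)c(OC)c(OC)c1)c1ccc(OC)cc1NC(=O)CO`: 30 nM
Compound 2 `COc1ccc(C(=O)c2cc(OC)c(OC)c(OC)c2)c(NC(=O)CN)c1`: 190 nM
Compound 3 `C=C(c1cc(OC)c(OC)c(OC)c1)c1ccc(OC)cc1NC(=O)CNC`: 140 nM

In a functional assay on A2780 cells (Homo sapiens) for antiproliferative activity, read by MTT assay, with a stated time of 48 h (a lower number here means a stronger inhibitor, a higher number a weaker inhibitor), compound 3 at 140 nM lies within the usual scatter of compound 2 at 190 nM, and the gap to compound 1 is larger: a 4.7-fold higher number from compound 1 to compound 3 (0.67 log units; beyond the scatter). Compound 4 `C=C(c1cc(OC)c(OC)c(OC)c1)c1ccc(OC)cc1NC(=O)CN(C)C` carries methyl in place of hydrogen on an amine nitrogen. Among the measured compounds shown here, no measured step makes this exact change. The nearest is a 4.7-fold higher number from compound 1 to compound 3 (0.67 log units; beyond the scatter), which replaces hydroxy with methylamino and so bears on it only loosely. In this assay, no step beyond the scatter is therefore expected, in either direction. The estimated step is a 1.1-fold higher number from compound 3 to compound 4 (0.03 log units; within the scatter). Compound 4 is expected at 150 nM, with an estimated range of 50 nM to 450 nM.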

Compound 4, half-maximal inhibitory concentration: 240 nM
Compound 4: middle estimate off by 1.6-fold (0.20 log units), on the low side; measured number inside the range.
By their numbers in this assay, from the lowest: compound 1; then compounds 3, 2 and 4 (each within the scatter of the next).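

In this assay, the second methyl on the amine nitrogen gives a 1.7-fold higher number from compound 3 to compound 4 (0.23 log units; within the scatter), so at this position the change from methylamino to dimethylamino cannot be told from the scatter. Measured against the hydroxy of compound 1, the dimethylamino group gives an 8.0-fold higher number from compound 1 to compound 4 (0.90 log units; beyond the scatter), so both amines on this core remain clearly weaker than the hydroxy compound. Nothing available explains these steps. From the compounds shown here alone, whether a piperidine, a morpholine or a longer chain carrying the dimethylamino group would come closer to compound 1 stays open, as does the unsubstituted amine on this same core.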